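Lengthening the Linker: Expected Cytotoxicity of Compound 3

This account rests on a few compounds, and the source may have more. Where it says the series, first, only, none or still open, it means among the compounds named here.

Compound 1 `N=C(N)c1ccc2cc(-c3ccc(OCCCCOc4ccccc4)cc3)oc2c1`: 14100 nM
Compound 2 `c1ccc(OCCCCOc2ccc(-c3cc4ccc(C5=NCCN5)cc4o3)cc2)cc1`: 16900 nM

In an ADME assay on L6 cells (Rattus norvegicus) for cytotoxicity, read by resazurin assay, with a stated time of 70 h (a lower number here means a stronger inhibitor, a higher number a weaker inhibitor), compound 1 gives 14100 nM, the lowest of the two numbers. Compound 2 gives 16900 nM. The step of a 1.2-fold higher number from compound 1 to compound 2 (0.08 log units; within the scatter) lies within the scatter. Compound 3 `N=C(N)c1ccc2cc(-c3ccc(OCCCCCCOc4ccccc4)cc3)oc2c1` differs from compound 1 by 2-phenoxyethyl in place of phenoxy on a saturated chain carbon, four bonds along the chain from an oxygen on an aromatic ring. Going by the values given here, the only measured step, a 1.2-fold higher number from compound 1 to compound 2 (0.08 log units; within the scatter), alters a different part of the shared core, so no measured step bears directly on this chain change. With that, the expected change from compound 1 to compound 3 in this assay is a 1.0-fold lower number from compound 1 to compound 3 (0.00 log units; within the scatter), none beyond the scatter. Compound 3 is estimated at 14000 nM, expected between 6000 nM and 33000 nM.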

Compound 3, half-maximal inhibitory concentration: 8000 nM
The estimate for compound 3 lay 1.8-fold (0.24 log units) above the measured number; the range from low to high includes it.
By their numbers in this assay, from the lowest: compounds 3, 1 and 2 (each within the scatter of the next, the first and the last beyond it).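

In this assay, replacing phenoxy with 2-phenoxyethyl on the saturated chain carbon gives a 1.8-fold lower number from compound 1 to compound 3 (0.25 log units; within the scatter). Going by these compounds alone, this is the first measured change to the chain itself, and the added length does not move the number beyond the scatter of repeat measurements. Nothing at hand explains the result.

From the compounds shown here alone, it remains open whether a still longer chain would leave the number within the scatter. Going by these compounds, it is also open what an amine or a carboxylic acid would do in place of the phenoxy group.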